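Hydroxyphenyl-substituted pyridine triols: cytotoxicity notes

The compounds below may be only part of what the source reports. "The series", "measured", "known", "first", "only" and "open" are said of these compounds alone.

Compound 1 `Oc1ccc(-c2cc(-c3cccc(O)c3)nc(-c3cccc(O)c3)c2)cc1` and compound 2 `Oc1cccc(-c2cc(-c3cccc(O)c3)nc(-c3cccc(O)c3)c2)c1` share a core; the change 3-hydroxyphenyl in place of 4-hydroxyphenyl on an aromatic carbon gave a 1.1-fold lower number from compound 1 to compound 2 (0.04 log units; within the scatter) in a functional assay on T47D cells (Homo sapiens) for cytotoxicity, read by CCK-8 assay, with a stated time of 4 days; a higher number here means a weaker inhibitor, a lower number a stronger inhibitor. In this assay compound 1 gives 2230 nM and compound 2 gives 2050 nM. Compound 3 `Oc1ccc(-c2cc(-c3ccccc3O)cc(-c3ccccc3O)n2)cc1` has a core that differs from that of compound 1, but the difference between the two cores is not broken down here; in this assay compound 3 gives 960 nM, the lowest of the three numbers and beyond the scatter from both others.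

Compound 4 `Oc1cccc(-c2cc(-c3ccccc3O)cc(-c3ccccc3O)n2)c1` is not yet measured. It differs from compound 3 by 3-hydroxyphenyl in place of 4-hydroxyphenyl on an aromatic carbon. This is the same kind of change as from compound 1 to compound 2, but not the same change: the place here is next to the ring nitrogen and meta to two 2-hydroxyphenyl groups, whereas there it was opposite the ring nitrogen and meta to two 3-hydroxyphenyl groups. The step from compound 3 to compound 4 in this assay is expected to be small, a 1.0-fold lower number from compound 3 to compound 4 (0.00 log units; within the scatter), because the earlier change gave a 1.1-fold lower number from compound 1 to compound 2 (0.04 log units; within the scatter). Compound 4 is estimated at 950 nM, with a likely range from 450 nM to 2000 nM.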

Compound 4, half-maximal inhibitory concentration: 5760 nM
The estimate for compound 4 lay 6.1-fold (0.78 log units) below the measured number, outside the stated range (above it).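

The change gave a 6.0-fold higher number from compound 3 to compound 4 (0.78 log units; beyond the scatter) in this assay, so the result from the first pair does not carry over to the core of compound 3: the same change on two cores in this assay, a 1.1-fold lower number (0.04 log units; within the scatter) from compound 1 to compound 2 and a 6.0-fold higher number (0.78 log units; beyond the scatter) from compound 3 to compound 4, 6.5-fold (0.81 log units) apart, beyond the scatter of two such steps

The outcome of this change therefore depends on the core it is made on, at least for these two pairs. It does not show which feature of the cores accounts for the gap, and one pair per core gives no rule for other cores in the series.

Still open, going by these compounds, is whether the two 2-hydroxyphenyl groups or the place of the exchanged ring matters more. Also open, on these data alone, is how an amine or a carboxylic acid in place of the hydroxyl on the exchanged ring would behave on either core.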